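The compounds below may be only part of what the source reports. "The series", "measured", "known", "first", "only" and "open" are said of these compounds alone.

In a toxicity assay on Vero cells (Chlorocebus sabaeus) for cytotoxicity, read by MTT assay (a higher number here means a weaker inhibitor, a lower number a stronger inhibitor), compound 3 `CCOC(=O)NC(=O)c1ccsc1NC(=O)c1ccc(S(=O)(=O)N2CCC2)cc1` gives > 64 ug/mL, which is a limit of the assay and not a number. Its standing is thus (the limit of > 64 ug/mL in this assay, at which 1 of the 3 values shown sits). Compound 4 `CCOC(=O)NC(=O)c1ccsc1NC(=O)c1ccc(S(=O)(=O)N2CCCC2)cc1` carries pyrrolidin-1-yl in place of azetidin-1-yl on a sulfonyl sulfur. Going by the values given here, the same exchange has been measured once, and it is the only step that bears on this one. There, compound 1 `COC(=O)NC(=O)c1ccsc1NC(=O)c1ccc(S(=O)(=O)N2CCC2)cc1` gives 17.5 ug/mL and compound 2 `COC(=O)NC(=O)c1ccsc1NC(=O)c1ccc(S(=O)(=O)N2CCCC2)cc1` gives 39.5 ug/mL, which is a 2.3-fold higher number from compound 1 to compound 2 (0.35 log units; beyond the scatter). A similarly modest move to a higher number is therefore expected in this assay, estimated as a step that the limit leaves unreadable from compound 3 to compound 4. For compound 4 the expected value is 100 ug/mL, with an estimated range of 50 ug/mL to 200 ug/mL.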

Compound 4, half-maximal inhibitory concentration: 58.2 ug/mL
Beside the measured number, compound 4's estimate is 1.7-fold (0.24 log units) above it; low and high end bracket the measured number.
By their numbers in this assay, from the lowest: compound 1; then compounds 2 and 4 (each within the scatter of the next). At a limit, above all of these: compound 3.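

Compound 3 gives > 64 ug/mL in this assay, which is a limit of the assay. Pyrrolidin-1-yl in place of azetidin-1-yl on a sulfonyl sulfur now appears on a second core as an at least 1.0-fold lower number from compound 3 to compound 4 (0.04 log units; that floor lies within the scatter), so the direction of this exchange there cannot be settled: the same change on two cores in this assay, a 2.3-fold higher number (0.35 log units; beyond the scatter) from compound 1 to compound 2 and an at least 1.0-fold lower number (0.04 log units; that floor lies within the scatter) from compound 3 to compound 4; the limit leaves it open whether they differ With pyrrolidin-1-yl on the sulfonyl sulfur, methyl in place of hydrogen on the saturated chain carbon gives a 1.5-fold higher number from compound 2 to compound 4 (0.17 log units; within the scatter), and whether this differs from the same change with azetidin-1-yl stays undecided: the same change on two cores in this assay, an at least 3.6-fold higher number (0.56 log units; beyond the scatter) from compound 1 to compound 3 and a 1.5-fold higher number (0.17 log units; within the scatter) from compound 2 to compound 4; the limit leaves it open whether they differ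

The compounds shown leave open how a piperidin-1-yl ring or an open-chain dimethylamino group on the sulfonyl sulfur would read in this assay.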